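Opening the ring arm on the thiocarbonyl carbon

The compounds below may be only part of what the source reports. "The series", "measured", "known", "first", "only" and "open" are said of these compounds alone.

For the measured compounds named here, compound 1 `Nc1ccccc1NC(=O)c1ccc(CSC(=S)N2CCc3cc(Cl)ccc32)cc1` was tested in a functional assay on HeLa cells (Homo sapiens) for antiproliferative activity, read by CCK-8 assay, with a stated time of 72 h, tested at 8 uM (on this read-out lower numbers stand for a weaker effect and higher numbers for a stronger effect at the one concentration tested), where compound 1 gives 65.1%, the lowest of the three numbers measured so far. Compound 2 `N#Cc1ccc(N2CCN(C(=S)SCc3ccc(C(=O)Nc4ccccc4N)cc3)CC2)cc1` gives 70.6%, and compound 3 `Nc1ccccc1NC(=O)c1ccc(CSC(=S)N2CCN(Cc3cccnc3)CC2)cc1` gives 78%. Compound 4 `CN(Cc1cccnc1)C(=S)SCc1ccc(C(=O)Nc2ccccc2N)cc1` differs from compound 1 in one place: methyl((pyridin-3-yl)methyl)amino in place of 5-chloro-2,3-dihydro-1H-indol-1-yl on a thiocarbonyl carbon. Going by the values given here, the only measured step that brings in a (pyridin-3-yl)methyl group is a number 7.4 percentage points higher from compound 2 to compound 3 (within the scatter), a change that stayed within the scatter. Compound 3, which carries this group, stands higher than compound 1 by more than the scatter. Compound 4 is therefore expected to give a similar or somewhat higher number, a step of a number 5.9 percentage points higher from compound 1 to compound 4 (within the scatter). The estimate for compound 4 is 71%, with a range from 58% to 84%.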

Compound 4, a percentage reported as inhibition, at one concentration (the size of the read-out at that concentration, not a potency): 68.7%
For compound 4 the middle estimate is 2.3 percentage points above the measured one; measured number inside the range.
By their numbers in this assay, from the lowest: compounds 1, 4, 2 and 3 (each within the scatter of the next, the first and the last beyond it).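

In this assay, the swap gives a number 3.6 percentage points higher from compound 1 to compound 4 (within the scatter), so the fused 5-chloro-2,3-dihydro-1H-indol-1-yl group is not needed on the thiocarbonyl carbon to keep a number of this size at the one concentration tested. An open-chain amine with no chlorine, methyl((pyridin-3-yl)methyl)amino, serves there as well. Nothing available explains why the two groups read alike.

The compounds shown leave open how an ethyl group or a longer chain in place of the methyl would read. A single concentration also says nothing about potency.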